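From compound 3 to compound 4: fluoro for chloro

The compounds below may be only part of what the source reports. "The series", "measured", "known", "first", "only" and "open" are said of these compounds alone.

Values in a functional assay on HeLa cells (Homo sapiens) for antiproliferative activity, read by MTT assay, with a stated time of 72 h (on this read-out higher numbers stand for weaker inhibition and lower numbers for stronger inhibition), are as follows:
compound 1 `COc1ccc(-c2ncnn2-c2cc(OC)c(OC)c(OC)c2)cc1` gives 280 nM
compound 2 `COc1cccc(-c2ncnn2-c2cc(OC)c(OC)c(OC)c2)c1` gives > 10000 nM (a limit)
compound 3 `COc1cc(-n2ncnc2-c2cccc(Cl)c2)cc(OC)c1OC` gives > 10000 nM (a limit)

Compound 3 has only a limit, which is the limit of > 10000 nM in this assay, at which 2 of the 3 values shown sit, in this series. Compound 4 `COc1cc(-n2ncnc2-c2cccc(F)c2)cc(OC)c1OC` carries fluoro in place of chloro on an aromatic carbon (3-chlorophenyl to 3-fluorophenyl). The step that the two limits leave unreadable from compound 2 to compound 3 gives no size to go on. Given an at least 35-fold higher number from compound 1 to compound 3 (1.55 log units; beyond the scatter) and an at least 35-fold higher number from compound 1 to compound 2 (1.55 log units; beyond the scatter) (both large, beyond the scatter, both away from the 4-methoxyphenyl), no step beyond the scatter is expected in this assay in either direction, as compound 4 lacks that group too. Compound 4 is estimated at 10000 nM (expected range 3000 nM to 30000 nM). The expected outcome is a number no higher from compound 3 to compound 4 (the limit leaves the size open) (an estimate).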

Compound 4, half-maximal inhibitory concentration: > 10000 nM
Compound 4 gave a limit, no number (the forecaster's own chance of this, stated with the estimate: 75%); the middle value sits exactly at the limit.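

In this assay, 3-fluorophenyl in place of 4-methoxyphenyl gives an at least 35-fold higher number from compound 1 to compound 4 (1.55 log units; beyond the scatter), so a fluoro at this place does not bring back a readable value in the absence of the 4-methoxyphenyl. The steps among compound 2, compound 3 and compound 4 cannot be read, and fluoro and chloro therefore cannot be told apart here. Compound 4 has a limit, not a number: the limit of > 10000 nM in this assay, at which 3 of the 4 values shown sit.

Still open, on these data alone, is how far compound 2, compound 3 and compound 4 differ beyond that limit. Also open, as far as these compounds go, is whether an amine or a hydroxy group in place of the methoxy of the 4-methoxyphenyl would keep a readable value.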